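The source may hold more compounds than are shown below. What is called first, only, known or untested is meant among the compounds shown, and "the series" means these compounds.

Measured so far in a functional assay on MDA-MB-231 cells (Homo sapiens) for antiproliferative activity, read by MTT assay, with a stated time of 48 h; a higher number here means a weaker inhibitor, a lower number a stronger inhibitor: compound 1 `Cc1cnc(Nc2ccc(Cl)cc2)nc1Nc1nc2ccccc2s1` gives > 50000 nM. Compound 2 `Cc1ccc2nc(Nc3nc(Nc4ccc(S(N)(=O)=O)cc4)ncc3C)sc2c1` gives 9080 nM. Compound 3 `COc1ccc2nc(Nc3nc(Nc4ccc(S(C)(=O)=O)cc4)ncc3F)sc2c1` gives 4740 nM.

The value of compound 1 is a limit of the assay, not a number; compound 1 is the only one of the three that sits at it (the limit of > 50000 nM in this assay, at which 1 of the 3 values shown sits). Compound 4 `COc1cccc(Nc2ncc(C)c(Nc3nc4ccccc4s3)n2)c1` differs from compound 1 by 3-methoxyphenyl in place of 4-chlorophenyl on a nitrogen on an aromatic ring. Among the compounds with values here, no measured pair differs in one place, so the size of this step has no anchor. Compounds 2 and 3 carry other groups on the corresponding nitrogen and return numbers rather than limits, so a move toward a measurable value is plausible but uncertain. Compound 4 is expected at 30000 nM, range 8000 nM to 100000 nM, an expected step of an at least 1.6-fold lower number from compound 1 to compound 4 (0.22 log units; that floor lies within the scatter).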

Compound 4, half-maximal inhibitory concentration: > 50000 nM
Compound 4: only a limit was reported; the forecaster's own chance of this, stated with the estimate: 40%; at least 1.6-fold (0.22 log units) between middle value and limit.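

Within the data shown here, compound 4, like compound 1, returns only a limit of the assay, so no step between the two can be read: the limit of > 50000 nM in this assay, at which 2 of the 4 values shown sit.
Still open, as far as these compounds go, is how far 3-methoxyphenyl and 4-chlorophenyl differ on this nitrogen, as both values remain limits.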